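The source may hold more compounds than are shown below. What is called first, only, known or untested is meant among the compounds shown, and "the series" means these compounds.

Working notes on the series. All three measured compounds share one core and differ only in the side arm attached to it. In a functional assay on UO-31 cells (Homo sapiens) for inhibition, read by sulforhodamine B assay, with a stated time of 48 h (a higher number here means a weaker inhibitor of growth, a lower number a stronger inhibitor of growth), compound 1 `Nc1cc(N)c2nc(-c3ccccc3)c(NCc3ccc(Cl)c(Cl)c3)nc2c1` gives 4170 nM and compound 3 `COc1cc(CNc2nc3cc(N)cc(N)c3nc2-c2ccccc2)cc(OC)c1OC` gives 11200 nM. Compound 2 `Nc1cc(N)c2nc(-c3ccccc3)c(Sc3ccc(F)cc3)nc2c1` is reported in this assay only as a limit, < 100000 nM, not as a number. Compound 2 therefore stands at the limit of < 100000 nM in this assay, at which 1 of the 3 values shown sits, and no figure is available to set against compound 1 or compound 3. Compound 4 `Nc1cc(N)c2nc(-c3ccccc3)c(Sc3ccc(Cl)c(Cl)c3)nc2c1` remains to be measured in this assay. The change from compound 2 to compound 4 is 3,4-dichlorophenyl in place of 4-fluorophenyl on a sulfur. Among the compounds with values here, no measured pair in the set differs in a single place, so the size of this step cannot be read from the data. Compound 1, which also carries a 3,4-dichlorophenyl though within a different side arm, returns a number rather than a limit, so a number in that region is expected for compound 4, with a real chance that only a limit comes back. The estimate for compound 4 in this assay is 20000 nM, within 3000 nM to 100000 nM, which corresponds to an expected step that the limit leaves unreadable from compound 2 to compound 4.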

Compound 4, concentration for 50% growth inhibition: 3800 nM
Estimate against measurement, compound 4: 5.3-fold (0.72 log units) above; low and high end bracket the measured number.
By their numbers in this assay, from the lowest: compounds 4 and 1 (each within the scatter of the next); then compound 3.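

No new step can be read from compound 2 to compound 4, because compound 2 is held only as a limit: the limit of < 100000 nM in this assay, at which 1 of the 4 values shown sits.

The compounds shown leave open what size the change from 4-fluorophenyl to 3,4-dichlorophenyl on a sulfur has when both partners carry a number.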